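A Ring in Place of 1-Hydroxyethyl

The compounds below may be only part of what the source reports. "The series", "measured", "known", "first", "only" and "open" are said of these compounds alone.

- compound 1 `CC(=O)c1nc([C@@H](O)[C@H](O)[C@H](O)CO)cn1C` gives 33.6%
- compound 2 `CC(O)c1nc([C@@H](O)[C@H](O)[C@H](O)CO)c[nH]1` gives 22%

In an in vivo ADME assay on the whole organism (strain 129/SvEvBrd x C57BL/6) for pharmacokinetics, with Mus musculus as the target (a higher number here means that a larger share of the oral dose reaches the circulation, a lower number that a smaller share of the oral dose reaches the circulation), compound 2 stands lowest of the two at 22%. The nearest number belongs to compound 1 at 33.6%, and that gap lies beyond the usual scatter. Compound 3 `OC[C@@H](O)[C@@H](O)[C@H](O)c1c[nH]c(-c2ncon2)n1` departs from compound 2 in one place: 1,2,4-oxadiazol-3-yl in place of 1-hydroxyethyl on an aromatic carbon. It carries 1,2,4-oxadiazol-3-yl in place of 1-hydroxyethyl on an aromatic carbon. Within the data shown here, no measured pair in this assay shows a change of this kind, so the two numbers at hand offer only a rough frame. A small rise is expected, with no shift beyond the scatter, and the direction remains uncertain. The estimated step is a number 3 percentage points higher from compound 2 to compound 3 (within the scatter). Compound 3 is expected at 25%, with an estimated range of 9% to 45%.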

Compound 3, oral bioavailability: 5%
Estimate against measurement, compound 3: 20 percentage points above; the measured number lies below the stated range.
By their numbers in this assay, from the lowest: compound 3; then compound 2; then compound 1.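

In this assay, among these compounds, 1,2,4-oxadiazol-3-yl in place of 1-hydroxyethyl gives a number 17 percentage points lower from compound 2 to compound 3 (beyond the scatter) and provides the first comparison of compounds that differ in one place. It shows that oral bioavailability responds to the group on this aromatic carbon, between two ring nitrogen atoms, and that a five-membered aromatic ring with 3 hetero atoms does not preserve the level seen with 1-hydroxyethyl. Nothing measured here accounts for the fall.

This single pair cannot separate the arrival of the ring from the loss of the hydrogen-bond donor carried by 1-hydroxyethyl, since the two changes come together. From the compounds shown here alone, how a plain ethyl group, an aminomethyl group or a phenyl ring on the same carbon would fare in this assay remains open.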